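A few compounds are considered here, and "the series" means these few. Any claim that something is new, unique, unknown or untested is made for them only; others in the source may bear on it.

The measured compounds and their values:

Compound 1 `Cc1nc(-c2cccc(C(=O)N3CCCC(C(=O)Nc4ccc(Cl)cc4)C3)c2)no1`, which in an ADME assay on PC-3 cells (Homo sapiens) for cytotoxicity, read by WST assay, tested at 100 uM (a higher number here means more inhibition at the concentration tested (going by the name of the read-out), a lower number less inhibition), gives 0%.
Compound 2 `O=C(Nc1cccc(Cc2ccccc2)c1)C1CCCN(C(=O)c2cccc(-c3ccco3)c2)C1`, which in this assay gives 0%.
Compound 3 `O=C(Nc1ccc(Cl)cc1)C1CCCN(C(=O)c2cc(C(F)(F)F)cc(C(F)(F)F)c2)C1`, which in this assay gives 14%.

Compound 1 stands level with compound 2 at the digits reported, and together these two are the lowest of the three numbers; the two values lie within the usual scatter of each other, so no order can be drawn between them. Compound 3 is the furthest from compound 1, its value sitting higher by an amount that lies beyond the scatter, and it is the only one of the three to show any inhibition worth the name.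

The step considered here leads from compound 1 to compound 4 `O=C(Nc1ccc(Cl)cc1)C1CCCN(C(=O)c2cccc(-c3ccco3)c2)C1`. The change is furan-2-yl in place of 5-methyl-1,2,4-oxadiazol-3-yl on an aromatic carbon. The group that enters is the same furan-2-yl that compound 2 already carries on its core, and compound 2 sits at the bottom of the range alongside compound 1. On that basis no step beyond the scatter is expected in this assay, in either direction, because both compound 1 at 0% and compound 2 at 0% show no inhibition at the tested concentration.

For compound 4 the estimated value is 3%, with a range from 0% to 12%, which means an expected step of a number 3 percentage points higher from compound 1 to compound 4 (within the scatter).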

Compound 4, a percentage reported as inhibition, at one concentration (the size of the read-out at that concentration, not a potency): 0%
Compound 4: middle estimate off by 3 percentage points, on the high side, and the stated range covers the measured number.
By their numbers in this assay, from the lowest: compounds 1, 2 and 4 (each within the scatter of the next); then compound 3.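

In this assay, furan-2-yl in place of 5-methyl-1,2,4-oxadiazol-3-yl on an aromatic carbon, meta to a large group, brings no change at the digits printed from compound 1 to compound 4 (within the scatter). Within the data shown here, this is the first comparison in the set between compounds that differ in one place, and it shows that a five-membered aromatic ring with 1 hetero atom can stand where one with 3 hetero atoms stood without moving the read-out, although neither compound shows any inhibition that a loss could be measured from. Nothing available explains this outcome.

Going by these compounds, what the position can do in the other direction stays open, since an amine or a carboxylic acid on the same aromatic carbon could leave the number where it is or raise it, and the furan-2-yl result does not tell which. Compound 3, at 14%, also remains unconnected to the others by any one-place step, so its two trifluoromethyl groups cannot yet be tied to that value.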